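A few compounds are considered here, and "the series" means these few. Any claim that something is new, unique, unknown or untested is made for them only; others in the source may bear on it.

Compound 1 `CC(C)OC(=O)C(C)ON1C(=O)c2ccccc2C1=O`: 51% in a functional assay on the whole organism for inhibition, with Lepidium sativum as the target, tested at 1 ppm; on this read-out higher numbers stand for more inhibition of growth at the one concentration tested and lower numbers for less inhibition of growth.
Compound 2 `CCCCOC(=O)C(C)ON1C(=O)c2ccccc2C1=O`: 59% in this assay.
Compound 3 `CCCC(C)ON1C(=O)c2ccccc2C1=O`: 0% in this assay.

Compound 3 stands lowest of the three numbers; its nearest neighbour is compound 1 and its furthest compound 2, both beyond the scatter. Compound 4 `CCC(C)OC(=O)C(C)ON1C(=O)c2ccccc2C1=O` is not yet measured. Relative to compound 3 the change is sec-butoxycarbonyl in place of propyl on a saturated chain carbon bound to an oxygen on an unsaturated carbon and a saturated chain carbon. Going by the values given here, the steps that bear on it run the other way: a number 51 percentage points lower from compound 1 to compound 3 (beyond the scatter) and a number 59 percentage points lower from compound 2 to compound 3 (beyond the scatter), both large. Compound 1 and compound 2 lie within the scatter of each other, a number 8 percentage points higher from compound 1 to compound 2 (within the scatter). A large rise in this assay from compound 3 to compound 4 is therefore expected, back to the level of compounds 1 and 2, that is a number 55 percentage points higher from compound 3 to compound 4 (beyond the scatter). Compound 4 is estimated at 55%, between 35% and 75%.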

Compound 4, percent growth inhibition at one concentration: 42%
Beside the measured number, compound 4's estimate is 13 percentage points above it; the range from low to high includes it.
By their numbers in this assay, from the lowest: compound 3; then compounds 4, 1 and 2 (each within the scatter of the next, the first and the last beyond it).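

Sec-butoxycarbonyl in place of propyl gives a number 42 percentage points higher from compound 3 to compound 4 (beyond the scatter) in this assay at this carbon, so the gain seen with compound 1 and compound 2 also holds for a third oxycarbonyl group. The alkyl part still counts to a limited degree: sec-butyl in place of butyl on an oxygen next to a carbonyl group gives a number 17 percentage points lower from compound 2 to compound 4 (beyond the scatter) as a modest loss, while methyl in place of hydrogen gives a number 9 percentage points lower from compound 1 to compound 4 (within the scatter) and no readable change.

No measurement available here accounts for these steps. Open, from the compounds shown here alone, is whether a carboxylic acid or an amide at this carbon keeps the gain, and what a longer chain on the oxygen does.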